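Amide-ring swap on the spiro series: sulfonylpiperazine to hydroxypiperidine

A few compounds are considered here, and "the series" means these few. Any claim that something is new, unique, unknown or untested is made for them only; others in the source may bear on it.

Working notes. Two compounds of the series have numbers in an assay on HEK293 cells for displacement of a labelled ligand from NPC1-like intracellular cholesterol transporter 1 (Homo sapiens); on this read-out higher numbers stand for weaker inhibition and lower numbers for stronger inhibition. Compound 1 `O=C(CN1CN(c2ccccc2)C2(CCN(C(=O)c3ccc(C4CCCCC4)cc3)CC2)C1=O)N1CCC(CO)CC1` gives 1100 nM in this assay. Within the data shown here, compound 2 `CC(C)(C)c1ccc(C(=O)N2CCC3(CC2)C(=O)N(CC(=O)N2CCN(S(C)(=O)=O)CC2)CN3c2ccccc2)cc1` gives 19000 nM and so stands at the highest of the two numbers, a gap to compound 1 that lies beyond the scatter; the two differ in more than one place, so no single step is assigned.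

Compound 3 `CC(C)(C)c1ccc(C(=O)N2CCC3(CC2)C(=O)N(CC(=O)N2CCCC(O)C2)CN3c2ccccc2)cc1` differs from compound 2 in one place: 3-hydroxypiperidin-1-yl in place of 4-(methylsulfonyl)piperazin-1-yl on a carbonyl carbon. Among the measured compounds shown here, no measured pair isolates this change. A step toward lower numbers is expected, moderate rather than large, resting only on compound 1, whose amide ring also carries a hydroxyl and which gives 1100 nM; the estimated step is a 2.4-fold lower number from compound 2 to compound 3 (0.38 log units; beyond the scatter). Compound 3 is thus expected at about 8000 nM in this assay, within a range of 2500 nM to 25000 nM.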

Compound 3, half-maximal inhibitory concentration: 12200 nM
Beside the measured number, compound 3's estimate is 1.5-fold (0.18 log units) below it; low and high end bracket the measured number.
By their numbers in this assay, from the lowest: compound 1; then compounds 3 and 2 (each within the scatter of the next).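

In this assay, 3-hydroxypiperidin-1-yl in place of 4-(methylsulfonyl)piperazin-1-yl on a carbonyl carbon gives a 1.6-fold lower number from compound 2 to compound 3 (0.19 log units; within the scatter), so this position tolerates the loss of the sulfonyl-bearing ring and the arrival of a hydrogen-bond donor without a change that can be told from the scatter. Among these compounds, this pair gives the first single-place reading at the position, and it separates neither amide ring from the other. No measurement at hand accounts for this result.

Still open, going by these compounds, is whether a piperidine ring carrying an amine or a carboxylic acid on this carbonyl carbon would give a step beyond the scatter. Also open, on these data alone, is how 3-hydroxypiperidin-1-yl reads when cyclohexyl takes the place of the tert-butyl group.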